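A few compounds are considered here, and "the series" means these few. Any claim that something is new, unique, unknown or untested is made for them only; others in the source may bear on it.

Measured so far: compound 1 `CNc1nc(NCCCN(C)C)c2sc(-c3ccc(N)cc3)cc2n1` with 2.3; compound 2 `CNc1nc(NCCCN(C)C)c2sc(-c3ccc(NS(C)(=O)=O)cc3)cc2n1` with 2.1.

In a physicochemical assay for lipophilicity, read by HPLC, at pH 7.4 (on this read-out higher numbers stand for higher lipophilicity and lower numbers for lower lipophilicity), compound 2 holds the lowest of the two numbers, with compound 1 nearest at a number 0.20 log units lower from compound 1 to compound 2 (within the scatter). Compound 3 `CNc1nc(NCCCN(C)C)c2sc(-c3ccc(N4CCNCC4)cc3)cc2n1` differs from compound 2 by piperazin-1-yl in place of methanesulfonamido on an aromatic carbon. No measured step covers this exchange; the one step shown, a number 0.20 log units lower from compound 1 to compound 2 (within the scatter), is within the scatter and gives no guidance beyond that. For compound 3 a fall beyond the scatter is expected, as a step of a number 0.60 log units lower from compound 2 to compound 3 (beyond the scatter). The estimate for compound 3 is 1.5, with a range from 0.8 to 2.2.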

Compound 3, distribution coefficient: 3.5
For compound 3 the middle estimate is 2.00 log units below the measured one; the measured number lies above the stated range.
By their numbers in this assay, from the lowest: compounds 2 and 1 (each within the scatter of the next); then compound 3.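

Large shifts are possible on this aromatic carbon para to a large group: a number 1.40 log units higher from compound 2 to compound 3 (beyond the scatter) and a number 1.20 log units higher from compound 1 to compound 3 (beyond the scatter) in this assay while the only earlier step here stayed within the scatter. Piperazin-1-yl thus stands apart from both amino and methanesulfonamido, even though piperazin-1-yl and methanesulfonamido count the same hydrogen-bond donors and acceptors. No supporting data explain this shift.

Going by these compounds, whether the shift follows the six-membered ring itself or its second nitrogen remains open. Morpholine or piperidine at the same place would separate these two readings.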